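Swapping a Halogenated Phenyl Group on the Sulfur Linker

A few compounds are considered here, and "the series" means these few. Any claim that something is new, unique, unknown or untested is made for them only; others in the source may bear on it.

Of the compounds shown here, three sharing one core have been measured in an assay on isolated protein for binding affinity to Equilibrative nucleoside transporter 1 (Homo sapiens); on this read-out lower numbers stand for stronger inhibition and higher numbers for weaker inhibition. Compound 1, `OC[C@H]1O[C@@H](n2cnc3c(SC4CCCCC4)ncnc32)[C@H](O)[C@@H]1O`, carries a cyclohexyl group on its sulfur and gives 6310 nM in this assay. Compound 2, `Cc1ccc(CSc2ncnc3c2ncn3[C@@H]2O[C@H](CO)[C@@H](O)[C@H]2O)cc1`, gives 457 nM. Compound 3, `OC[C@H]1O[C@@H](n2cnc3c(CSc4ccccc4I)ncnc32)[C@H](O)[C@@H]1O`, gives 282 nM, the lowest of the three numbers; the gap to compound 2 stays within the scatter, while the gap to compound 1 is large, so compound 3 cannot be set apart from compound 2 on these numbers alone.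

Compound 4, `OC[C@H]1O[C@@H](n2cnc3c(CSc4cccc(Cl)c4)ncnc32)[C@H](O)[C@@H]1O`, differs from compound 3 by 3-chlorophenyl in place of 2-iodophenyl on a sulfur. Going by the values given here, the steps that bear on this change are a 22-fold lower number from compound 1 to compound 3 (1.35 log units; beyond the scatter) and a 14-fold lower number from compound 1 to compound 2 (1.14 log units; beyond the scatter), both of which replace a cyclohexyl with an aromatic group, and a 1.6-fold lower number from compound 2 to compound 3 (0.21 log units; within the scatter), which exchanges one aromatic group for another. The first two are large, but they concern the loss of a saturated ring, which does not happen here. The third, an aryl-for-aryl exchange, stays within the scatter. On that basis the move to compound 4 is expected to be a 1.2-fold higher number from compound 3 to compound 4 (0.09 log units; within the scatter), not beyond the scatter in either direction, and compound 4 is estimated at 350 nM in this assay, within a range of 120 nM to 1000 nM.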

Compound 4, half-maximal inhibitory concentration: 282 nM
Compound 4: the middle estimate sits 1.2-fold (0.09 log units) above what was measured; the range from low to high includes it.
By their numbers in this assay, from the lowest: compounds 3, 4 and 2 (each within the scatter of the next); then compound 1.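

Replacing 2-iodophenyl with 3-chlorophenyl on a sulfur whose other neighbour is a saturated chain carbon gives [ no change at the digits printed from compound 3 to compound 4 (within the scatter) ] in this assay, so this change of both the halogen and its place on the ring leaves the read-out within the scatter. Compound 4 also joins the group that cannot be told apart on these numbers, with [ a 1.6-fold lower number from compound 2 to compound 4 (0.21 log units; within the scatter) ], while the large separation from the cyclohexyl-bearing member of the set persists, with [ a 22-fold lower number from compound 1 to compound 4 (1.35 log units; beyond the scatter) ]. No measurement at hand offers an explanation for why these aromatic groups cannot be told apart.

Since the halogen and its place change together, the compounds shown cannot say what either change does alone, which a pair such as 2-chlorophenyl and 3-chlorophenyl could separate. They also leave open whether an unsubstituted phenyl, a phenyl carrying an amine or a carboxylic acid, or a longer chain between the sulfur and the ring would stay within the scatter of compounds 2, 3 and 4.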